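The source may hold more compounds than are shown below. What is called first, only, known or untested is meant among the compounds shown, and "the series" means these compounds.

Measured so far in a functional assay on HepG2 cells (Homo sapiens) for antiproliferative activity, read by MTT assay, with a stated time of 48 h; a higher number here means a weaker inhibitor, a lower number a stronger inhibitor
- compound 1 `O=C(Nc1ccccc1)Nc1cccc(CNc2nccnc2Cl)c1` gives 15600 nM 
- compound 2 `O=C(Nc1cccc(CNc2nccnc2Cl)c1)Nc1ccc(F)c(Cl)c1` gives 6750 nM 
- compound 3 `Cc1ccccc1NC(=O)Nc1cccc(CNc2nccnc2Cl)c1` gives 15300 nM 

Compound 1 sits at the top of this small range, level with compound 3 within the scatter. Compound 4 `O=C(Nc1ccc(C(F)(F)F)cc1)Nc1cccc(CNc2nccnc2Cl)c1` follows from compound 1 by trifluoromethyl in place of hydrogen on an aromatic carbon (trifluoromethyl in place of hydrogen on an aromatic carbon, para to a large group). On the same phenyl, a methyl leaves the number unmoved (a 1.0-fold lower number from compound 1 to compound 3 (0.01 log units; within the scatter)) and 3-chloro-4-fluorophenyl lowers it modestly (a 2.3-fold lower number from compound 1 to compound 2 (0.36 log units; beyond the scatter)). Going by the values given here, no trifluoromethyl example has been measured. Compound 2 (6750 nM) is taken as the nearer guide, so a similar modest drop is expected in this assay rather than a large one. The estimated step is a 2.1-fold lower number from compound 1 to compound 4 (0.32 log units; beyond the scatter) in that direction. For compound 4 the expected value is 7500 nM with an estimated range from 3000 nM to 16000 nM here.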

Compound 4, half-maximal inhibitory concentration: 5050 nM
Beside the measured number, compound 4's estimate is 1.5-fold (0.17 log units) above it, and the stated range covers the measured number.
By their numbers in this assay, from the lowest: compounds 4 and 2 (each within the scatter of the next); then compounds 3 and 1 (each within the scatter of the next).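

In this assay, a substituent of 4 heavy atoms on this aromatic carbon, para to a large group, is tolerated and brings a modest improvement, a 3.1-fold lower number from compound 1 to compound 4 (0.49 log units; beyond the scatter). With this one group, compound 4 at 5050 nM stands within the scatter of the 3-chloro-4-fluorophenyl compound 2 at 6750 nM. Nothing available explains the step.

Open, from the compounds shown here alone, is whether the step is specific to trifluoromethyl or would also follow from a chlorine, a methoxy group or a nitrile at this position. Going by these compounds, a basic amine or a carboxylic acid there also remains untested in these compounds.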